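From 3-methylphenyl to 4-methylphenyl at compound 4

The source may report more compounds than this note shows. Statements on the series, on what has been measured and on what is new or still open speak of the compounds shown alone.

Measured in a functional assay on DU-145 cells (Homo sapiens) for cytotoxicity, in the presence of a further agent that is not named here (a higher number here means a weaker inhibitor, a lower number a stronger inhibitor), so far:
- compound 1 `Cc1cccc(-c2cc(-c3ccc(Cl)o3)cc(-c3ccsc3)n2)c1` gives 17900 nM
- compound 2 `Clc1cccc(-c2cc(-c3ccc(Cl)o3)cc(-c3cccs3)n2)c1` gives 18100 nM
- compound 3 `Clc1ccc(-c2cc(-c3ccco3)cc(-c3cccs3)n2)cc1` gives > 100000 nM as a limit

In this assay compound 1 gives 17900 nM and sits level with compound 2 within the usual scatter. Compound 3 has only a limit, > 100000 nM and no exact number.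

Compound 4 `Cc1ccc(-c2cc(-c3ccc(Cl)o3)cc(-c3ccsc3)n2)cc1` has the same atoms as compound 1, joined differently, with 4-methylphenyl in place of 3-methylphenyl on an aromatic carbon. Among the compounds with values here, no measured pair here differs in only one place, so this comparison has no direct precedent. No shift beyond the scatter is expected in this assay for this change. The expected step of a 1.1-fold higher number from compound 1 to compound 4 (0.05 log units; within the scatter) is small. Compound 4 is estimated at 20000 nM with an expected range of 8000 nM to 50000 nM in this measurement.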

Compound 4, half-maximal inhibitory concentration: 21200 nM
Compound 4: middle estimate off by 1.1-fold (0.03 log units), on the low side, and the stated range covers the measured number.
By their numbers in this assay, from the lowest: compounds 1, 2 and 4 (each within the scatter of the next). At a limit, above all of these: compound 3.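

Within the data shown here, the swap of 3-methylphenyl for 4-methylphenyl is the first comparison here that differs in only one place, and in this assay it gives a 1.2-fold higher number from compound 1 to compound 4 (0.07 log units; within the scatter). On this aryl group next to the ring nitrogen, moving the methyl therefore leaves the number unchanged within the scatter. Nothing measured here gives a reason for this.

Still open, as far as these compounds go, is whether a different group on that phenyl ring, such as an amine or a carboxylic acid, would shift the number. From the compounds shown here alone, it is also open whether the same methyl move stays silent when thiophen-3-yl is replaced by another ring.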